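Replacing pyridin-2-yl with 3-chlorophenyl

The compounds below may be only part of what the source reports. "The series", "measured", "known", "first", "only" and "open" are said of these compounds alone.

Three compounds share one core and differ only in the group on an oxygen on an aromatic ring. In an ADME assay on MRC5 cells (Homo sapiens) for cytotoxicity, read by fluorescence and resazurin assay, with a stated time of 3 days (on this read-out higher numbers stand for weaker inhibition and lower numbers for stronger inhibition), compound 1 (`Cc1cn(C2CCN(Cc3cccc(OC4CCCC4)c3)CC2)c(=O)[nH]c1=O`), with cyclopentyl, gives 30300 nM, and compound 2 (`Cc1cn(C2CCN(Cc3cccc(Oc4cc(Cl)cc(Cl)c4)c3)CC2)c(=O)[nH]c1=O`), with 3,5-dichlorophenyl, gives 6730 nM. Compound 3 (`Cc1cn(C2CCN(Cc3cccc(Oc4ccccn4)c3)CC2)c(=O)[nH]c1=O`), with pyridin-2-yl, gives > 64000 nM, which is a limit of the assay and not a number. That limit makes it the highest reading of the three.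

Compound 4 (`Cc1cn(C2CCN(Cc3cccc(Oc4cccc(Cl)c4)c3)CC2)c(=O)[nH]c1=O`) changes this one group: 3-chlorophenyl in place of pyridin-2-yl on an oxygen on an aromatic ring. The closest guide is the measured step of an at least 9.5-fold higher number from compound 2 to compound 3 (0.97 log units; beyond the scatter), which is beyond the scatter. The steps of an at least 2.1-fold higher number from compound 1 to compound 3 (0.32 log units; beyond the scatter) and a 4.5-fold lower number from compound 1 to compound 2 (0.65 log units; beyond the scatter) point the same way. Of the measured groups, 3-chlorophenyl most resembles the 3,5-dichlorophenyl of compound 2, so a clear fall in the number is expected, though perhaps not all the way to compound 2. The expected change is an at least 4.5-fold lower number from compound 3 to compound 4 (0.66 log units; beyond the scatter). Compound 4 is estimated at 14000 nM, with an expected range of 6500 nM to 32000 nM.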

Compound 4, half-maximal inhibitory concentration: 21000 nM
For compound 4 the middle estimate is 1.5-fold (0.18 log units) below the measured one; low and high end bracket the measured number.
By their numbers in this assay, from the lowest: compound 2; then compounds 4 and 1 (each within the scatter of the next). At a limit, above all of these: compound 3.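

In this assay, 3-chlorophenyl in place of pyridin-2-yl gives an at least 3.0-fold lower number from compound 3 to compound 4 (0.48 log units; beyond the scatter), a size that is only a bound because compound 3 sits at a limit of the assay: the limit of > 64000 nM in this assay, at which 1 of the 4 values shown sits.

The second chloro of the 3,5-dichlorophenyl also counts on its own, since hydrogen in its place gives a 3.1-fold higher number from compound 2 to compound 4 (0.49 log units; beyond the scatter). Against cyclopentyl, 3-chlorophenyl gives a 1.4-fold lower number from compound 1 to compound 4 (0.16 log units; within the scatter), so these two groups cannot be told apart on this read-out.

Going from compound 3 to compound 4 removes the ring nitrogen and adds a chloro in a single change, so the share of each stays open; a plain phenyl on this oxygen would separate them. As far as these compounds go, how a methoxy or a carboxylic acid in place of the chloro would read also stays open.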